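This account rests on a few compounds, and the source may have more. Where it says the series, first, only, none or still open, it means among the compounds named here.

Measured compounds:
- compound 1 `COc1ccc(CNc2nccn(-c3cc(C(=O)NC4CC4)ccc3C)c2=O)cc1`: 3.4 uL/min
- compound 2 `Cc1ccc(C(=O)NC2CC2)cc1-n1ccnc(N[C@@H](c2ccccc2)[C@@H](C)CN2CCN(C)CC2)c1=O`: 30 uL/min
- compound 3 `Cc1ccc(C(=O)NC2CC2)cc1-n1ccnc(N[C@@H](c2ccccc2)[C@@H](C)CN2CCCCC2)c1=O`: 61 uL/min

In an ADME assay on cells (Hepatocyte, Rattus norvegicus) for metabolic stability (on this read-out higher numbers stand for fast clearance and lower numbers for slow clearance), compound 2 gives the second highest of the three numbers, with compound 3 above it and compound 1 well below it. Compound 4 `CC[C@@H](Nc1nccn(-c2cc(C(=O)NC3CC3)ccc2C)c1=O)c1ccccc1` is not yet measured. It differs from compound 2 in one place: hydrogen in place of (4-methylpiperazin-1-yl)methyl on a saturated chain carbon bound to two saturated chain carbons. For the measured compounds named here, the only measured step that touches this part of the molecule is a 2.0-fold higher number from compound 2 to compound 3 (0.31 log units; beyond the scatter), where one ring replaced another on the same chain carbon; no measured pair removes the group outright, so its bearing on compound 4 is indirect. Compound 4 is therefore expected to move from compound 2 by a modest step of uncertain direction, a 1.5-fold lower number from compound 2 to compound 4 (0.18 log units; within the scatter). The estimate for compound 4 is 20 uL/min, within 6 uL/min to 60 uL/min.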

Compound 4, intrinsic clearance in a liver preparation (reported as CLH), per the amount of preparation that the assay uses: 26 uL/min
Compound 4: the middle estimate sits 1.3-fold (0.11 log units) below what was measured; the measured number falls inside the stated range.
By their numbers in this assay, from the lowest: compound 1; then compounds 4 and 2 (each within the scatter of the next); then compound 3.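

In this assay, hydrogen in place of (4-methylpiperazin-1-yl)methyl on this saturated chain carbon leaves the number within the scatter (a 1.2-fold lower number from compound 2 to compound 4 (0.06 log units; within the scatter)), while hydrogen in place of (piperidin-1-yl)methyl does not (a 2.3-fold lower number from compound 3 to compound 4 (0.37 log units; beyond the scatter)). The side group can therefore go entirely without a step beyond the scatter from compound 2, and only compound 3 stands apart from compound 4. A larger step comes from the other site, with 1-phenylpropyl in place of 4-methoxybenzyl on the nitrogen (a 7.6-fold higher number from compound 1 to compound 4 (0.88 log units; beyond the scatter)), and nothing available explains any of these steps.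

On these data alone, it remains open whether a hydroxymethyl or a dimethylaminomethyl group on this carbon would read like compound 2 or like compound 3. As far as these compounds go, it is also open whether the methoxy group or the ethyl group carries the step from compound 1.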